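This account rests on a few compounds, and the source may have more. Where it says the series, first, only, none or still open, it means among the compounds named here.

Of the compounds shown here, two have so far been measured in a functional assay on MDA-MB-231 cells (Homo sapiens) for cytotoxicity, read by MTT assay, with a stated time of 72 h; on this read-out higher numbers stand for weaker inhibition and lower numbers for stronger inhibition. Compound 1 `CCN(CC)CCNc1nc(-c2ccc(NC(=O)Nc3ccc(Cl)cc3)cc2)nc2c(Cl)c(Cl)sc12` gives 750 nM in this assay, and compound 2 `CCN(CC)CCNc1nc(-c2ccc(NC(=O)Nc3ccccc3Cl)cc2)nc2c(Cl)c(Cl)sc12` gives 1410 nM. Among the measured compounds shown here, of these two numbers, compound 2 holds the higher one, and its nearest neighbour is compound 1; the single measured step between them, a 1.9-fold higher number from compound 1 to compound 2 (0.27 log units; within the scatter), lies within the usual scatter, so the two compounds cannot be told apart on this assay.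

Compound 3 `CCN(CC)CCNc1nc(-c2ccc(NC(=O)Nc3ccc(Cl)cc3Cl)cc2)nc2c(Cl)c(Cl)sc12` keeps the shared core of compound 2 and differs from it only in chloro in place of hydrogen on an aromatic carbon, so it carries at the same time the two chloro groups that compound 1 and compound 2 each carry singly. For the measured compounds named here, no measured step adds a chloro group to this ring; the only step available, from compound 1 to compound 2, merely exchanged one chloro placement for the other and stayed within the scatter. On that basis the step from compound 2 to compound 3 is expected to be small, a 1.3-fold lower number from compound 2 to compound 3 (0.11 log units; within the scatter), with no clear direction. Compound 3 is therefore estimated at 1100 nM in this assay, with a likely range from 400 nM to 3000 nM.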

Compound 3, half-maximal inhibitory concentration: 1920 nM
For compound 3 the middle estimate is 1.7-fold (0.24 log units) below the measured one; the measured number falls inside the stated range.
By their numbers in this assay, from the lowest: compounds 1, 2 and 3 (each within the scatter of the next, the first and the last beyond it).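

In this assay, among the compounds shown here, this is the first result in which a chloro group is added to the ring rather than moved around it, and turning the 2-chlorophenyl of compound 2 into the 2,4-dichlorophenyl of compound 3 gives a 1.4-fold higher number from compound 2 to compound 3 (0.13 log units; within the scatter), so this added chloro, para to the large group, produces no readable change. Read from the other side, adding a chloro to the 4-chlorophenyl ring gives a 2.6-fold higher number from compound 1 to compound 3 (0.41 log units; beyond the scatter), a modest but real separation that shows the second chloro is not without consequence in every case, and that carrying both chloro groups brings no gain over compound 1 on this read-out. For the compounds shown here, nothing measured here explains why the two additions differ in outcome, and with only three compounds this comparison rests on a single ring and a single kind of group.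

What the compounds shown leave open is how the unsubstituted phenyl ring would compare with these chlorinated rings. On these data alone, it is also open whether a smaller fluoro group or a methoxy group in these same places would behave as chloro does.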